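A few compounds are considered here, and "the series" means these few. Any claim that something is new, unique, unknown or untested is made for them only; others in the source may bear on it.

In a functional assay on the whole organism with Rattus norvegicus as the target, with a stated time of 4 h, at a dose of 40 mg/kg by the intraperitoneal route (a lower number here means less inhibition, a higher number more inhibition at the dose given (going by the name of the read-out)), compound 2 `CCCCC(=O)OCc1c(C)nc2c(OCc3ccccc3)cccn12` gives 45%. Among the measured compounds shown here, compound 1 `Cc1nc2c(OCc3ccccc3)cccn2c1CCC#N` gives 40% in this assay, and the step of a number 5 percentage points higher from compound 1 to compound 2 (within the scatter) leaves compound 2 within the scatter of the only other number measured. Compound 3 `Cc1nc2c(OCc3ccccc3)cccn2c1C` carries hydrogen in place of (butylcarbonyl)oxy on a saturated chain carbon bound to an aromatic carbon. For the measured compounds named here, the one measured step that bears on this place, a number 5 percentage points higher from compound 1 to compound 2 (within the scatter), changed the group on that same carbon and stayed within the scatter. Compound 3 is therefore expected to show a number 5 percentage points lower from compound 2 to compound 3 (within the scatter), nothing beyond the scatter. Compound 3 is estimated at 40%, with a range from 25% to 55%.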

Compound 3, a percentage reported as inhibition, in the whole organism at one dose (the size of the read-out at that dose, not a potency): 99%
For compound 3 the middle estimate is 59 percentage points below the measured one; measured number above the stated range.
By their numbers in this assay, from the lowest: compounds 1 and 2 (each within the scatter of the next); then compound 3.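

In this assay, the group on the saturated chain carbon bound to an aromatic carbon turns out to matter greatly: hydrogen in place of (butylcarbonyl)oxy gives a number 54 percentage points higher from compound 2 to compound 3 (beyond the scatter), and hydrogen in place of cyanomethyl gives a number 59 percentage points higher from compound 1 to compound 3 (beyond the scatter). The two earlier groups differed little from each other, yet the plain methyl stands well apart from both. Nothing on hand accounts for this gap. From the compounds shown here alone, it remains open whether a hydroxyl or an amine on that carbon would hold the high number or fall back towards those of compound 1 and compound 2. An ethyl group in place of the methyl of compound 3 is equally untested ground for how small this substituent must stay.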